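The compounds below may be only part of what the source reports. "The series", "measured", "known", "first", "only" and "open" are said of these compounds alone.

Measured so far:
compound 1, `O=C1Nc2ccccc2/C1=N/NC(=S)N1CCN(c2ccccc2)CC1` — 24900 nM
compound 2, `O=C1Nc2ccc(F)cc2/C1=N/NC(=S)N1CCN(c2ccccc2)CC1` — 24300 nM
compound 3, `O=C1Nc2ccc(Cl)cc2/C1=N/NC(=S)N1CCN(c2ccccc2F)CC1` — 15200 nM

All three numbers come from a functional assay on MCF7 cells (Homo sapiens) for inhibition, read by MTT assay, with a stated time of 72 h; a lower number here means a stronger inhibitor, a higher number a weaker inhibitor. Compound 1 gives 24900 nM and compound 2 gives 24300 nM; the step between them, a 1.0-fold lower number from compound 1 to compound 2 (0.01 log units; within the scatter), is flat. The change is fluoro in place of hydrogen on an aromatic carbon. Compound 3 gives 15200 nM, and its gaps to compound 1 and to compound 2 both stay within the scatter, so nothing separates the three on this read-out. How the core of compound 3 differs from the core of compound 1 is not broken down here.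

Compound 4, `O=C1Nc2ccc(Cl)cc2/C1=N/NC(=S)N1CCN(c2ccc(F)cc2F)CC1`, is not yet measured. It differs from compound 3 by fluoro in place of hydrogen on an aromatic carbon, the same kind of change as that from compound 1 to compound 2, but not the same: there the fluoro entered on an aromatic carbon of a six-membered aromatic ring of carbon only, part of a fused or bridged system of two rings, meta to a fused ring and para to a fused ring; here it enters on a six-membered aromatic ring of carbon only, meta to a fluoro group and para to a large group.

Going by the values given here, the only measured instance of this kind of change is a 1.0-fold lower number from compound 1 to compound 2 (0.01 log units; within the scatter), which is flat; on that basis the step from compound 3 to compound 4 is expected to be a 1.1-fold lower number from compound 3 to compound 4 (0.04 log units; within the scatter), within the scatter. Among the compounds with values here, compound 4 is accordingly estimated at 14000 nM in this assay, with a range of 6000 nM to 35000 nM to allow for the fact that only one comparable step is known.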

Compound 4, half-maximal inhibitory concentration: 20100 nM
The estimate for compound 4 lay 1.4-fold (0.16 log units) below the measured number; low and high end bracket the measured number.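

In this assay, fluoro in place of hydrogen on an aromatic carbon, here 2-fluorophenyl to 2,4-difluorophenyl, gives a 1.3-fold higher number from compound 3 to compound 4 (0.12 log units; within the scatter), so this instance of the change is also flat. Set beside the earlier instance, the change reads alike on both cores, and the two steps cannot be told apart: the same change on two cores in this assay, a 1.0-fold lower number (0.01 log units; within the scatter) from compound 1 to compound 2 and a 1.3-fold higher number (0.12 log units; within the scatter) from compound 3 to compound 4, 1.4-fold (0.13 log units) apart, within the scatter of two such steps. Going by these compounds alone, this shows only that two flat steps agree: the fluoro enters a different ring in each pair, so the same site was not carried from one core to another, and neither pair shows whether a step of real size would carry over.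

The compounds shown leave open whether a different group on the phenyl ring in the place taken by fluoro in compound 4, such as methoxy, trifluoromethyl, an amine or a carboxylic acid, would move the number beyond the scatter. They also leave open how the 2-fluorophenyl to 2,4-difluorophenyl change reads on the core of compound 1, which would be a closer test of carrying this change between cores.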